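Phenyl for cyclohexyl on the oxygen: working notes

This account rests on a few compounds, and the source may have more. Where it says the series, first, only, none or still open, it means among the compounds named here.

Measured in a functional assay on M21 cells (Homo sapiens) for inhibition, read by sulforhodamine B assay, with a stated time of 48 h (on this read-out lower numbers stand for stronger inhibition of growth and higher numbers for weaker inhibition of growth), as follows
- compound 1 `c1ccc2cc(NC3=NCCO3)ccc2c1` gives 3500 nM
- compound 2 `c1cc(NC2=NCCO2)cc(OC2CCCC2)c1` gives 76900 nM
- compound 3 `c1cc(NC2=NCCO2)cc(OC2CCCCC2)c1` gives 12000 nM

Compound 3 at 12000 nM is the second highest of the three numbers, with compound 1 lower and compound 2 higher.

Next is compound 4 `c1ccc(Oc2cccc(NC3=NCCO3)c2)cc1` with phenyl in place of cyclohexyl on an oxygen on an aromatic ring. The difference phenyl in place of cyclohexyl on an oxygen on an aromatic ring is the whole of the change.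

Among the compounds with values here, one measured step bears on it, the modest 6.4-fold lower number from compound 2 to compound 3 (0.81 log units; beyond the scatter) with cyclohexyl in place of cyclopentyl on an oxygen on an aromatic ring. That step shows that the group on this oxygen can move the number beyond the scatter. Within the data shown here, no compound with an aromatic ring in this place has been measured, so the step sets no direction for phenyl. A step of similar size is possible either way in this assay but none beyond the scatter is the central expectation.

An estimated 1.2-fold lower number from compound 3 to compound 4 (0.08 log units; within the scatter) is the working expectation. For compound 4 the estimated value is 10000 nM with an expected range from 3000 nM to 35000 nM in this series.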

Compound 4, concentration for 50% growth inhibition: 9600 nM
The estimate for compound 4 lay 1.0-fold (0.02 log units) above the measured number; low and high end bracket the measured number.
By their numbers in this assay, from the lowest: compound 1; then compounds 4 and 3 (each within the scatter of the next); then compound 2.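

In this assay the first aromatic ring on this oxygen can be read against its saturated counterpart, and a 1.3-fold lower number from compound 3 to compound 4 (0.10 log units; within the scatter) leaves phenyl and cyclohexyl not told apart. Loss of the ring's saturation therefore does not register on this read-out, while an 8.0-fold lower number from compound 2 to compound 4 (0.90 log units; beyond the scatter) places compound 2 apart from the phenyl compound, so among compounds 2, 3 and 4 only the cyclopentyl compound stands out. Nothing at hand accounts for either step.

Open, on these data alone, is whether this tolerance holds once the phenyl ring carries a further group, such as an amine or a carboxylic acid. Also open, as far as these compounds go, is how a longer chain on the oxygen, in place of a ring, would read in this assay against these three compounds.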